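Methyl Placement on the Diaryl Triazole Series

This account rests on a few compounds, and the source may have more. Where it says the series, first, only, none or still open, it means among the compounds named here.

The shared core is that of compound 1, `c1ccc(-c2n[nH]c(-c3ccccc3)n2)cc1`, which in a functional assay on the whole organism (Cricetulus griseus) with Cricetinae gen. sp. as the target (a higher number here means that more compound is needed for the effect, a lower number that less compound is needed), gives 6 mg/kg. Compound 2, `Cc1ccc(-c2n[nH]c(-c3ccccc3)n2)cc1`, carries a methyl on one of the phenyl rings; in this assay compound 2 gives > 20 mg/kg, which is a limit of the assay rather than a number. Compound 2 therefore sits at the limit of > 20 mg/kg in this assay, at which 1 of the 3 values shown sits, and only a range is known for it. The measured step of an at least 3.3-fold higher number from compound 1 to compound 2 (0.52 log units; beyond the scatter) shows the first methyl costing potency. Compound 3, `Cc1ccc(-c2n[nH]c(-c3ccccc3)n2)c(C)c1`, adds a second methyl on the same phenyl ring and gives 0.2 mg/kg; the step of an at least 100-fold lower number from compound 2 to compound 3 (2.00 log units; beyond the scatter) is a large gain.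

Compound 4, `Cc1ccc(-c2n[nH]c(-c3ccccc3C)n2)cc1`, has not been measured. Relative to compound 2 the change is methyl in place of hydrogen on an aromatic carbon, on the other phenyl ring. The two measured steps both add a methyl to an aromatic carbon yet run in opposite directions, so neither settles the case. The step from compound 2 to compound 3, placed ortho to a large group as in compound 4, argues for a gain; the step from compound 1 to compound 2 warns that a methyl can also hurt. On balance a modest improvement is expected for compound 4, estimated as an at least 5.0-fold lower number from compound 2 to compound 4 (0.69 log units; beyond the scatter), giving 4 mg/kg with a range from 0.4 mg/kg to 30 mg/kg.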

Compound 4, dose for half-maximal effect: 20 mg/kg
Compound 4: middle estimate off by 5.0-fold (0.70 log units), on the low side, within the range that was stated.
By their numbers in this assay, from the lowest: compound 3; then compound 1; then compound 4.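

Methyl in place of hydrogen on the other phenyl ring, ortho to a large group, gives a number no higher from compound 2 to compound 4 (the limit leaves the size open) in this assay, so this position accepts the methyl without the number rising. Set against an at least 100-fold lower number from compound 2 to compound 3 (2.00 log units; beyond the scatter), which is the same change from the same parent, this shows that placement ortho to a large group does not alone secure a gain of readable size, and that the place of the methyl on the two rings has to be treated case by case. The value of compound 2 is a limit and not a number, so the size of the step to compound 4 cannot be read: the limit of > 20 mg/kg in this assay, at which 1 of the 4 values shown sits.

Open, as far as these compounds go, is the real number for compound 2, and with it whether the methyl of compound 4 brings a small gain, a large one or hardly any. Also open, from the compounds shown here alone, is how this position on the other phenyl ring responds to groups other than methyl, such as an ethyl chain, a methoxy group, a chlorine atom or an amine.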